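The compounds below may be only part of what the source reports. "The series", "measured", "known", "first", "only" and "open" are said of these compounds alone.

Working notes on the series. Going by the values given here, in a functional assay on MGC-803 cells (Homo sapiens) for inhibition, read by MTT assay, with a stated time of 72 h (a lower number here means a stronger inhibitor, a higher number a weaker inhibitor), compound 1 (`C#CCSc1nc2nc(C)cc(Nc3cc(-c4ccccc4)[nH]n3)n2n1`) gives 13400 nM and compound 2 (`COc1ccc(CSc2nc3nc(C)cc(Nc4cc(-c5ccccc5)[nH]n4)n3n2)cc1`) gives 3170 nM as the lower of the two numbers measured so far. Compound 3 (`Cc1cc(Nc2cc(-c3ccccc3)[nH]n2)n2nc(SCC3CC3)nc2n1`) has not yet been measured.

The change on going from compound 2 to compound 3 is cyclopropyl in place of 4-methoxyphenyl on a saturated chain carbon bound to a sulfur and it amounts to cyclopropyl in place of 4-methoxyphenyl on a saturated chain carbon bound to a sulfur.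

Among the compounds with values here, only one measured step bears on this: a 4.2-fold lower number from compound 1 to compound 2 (0.63 log units; beyond the scatter) is the change that brought in 4-methoxyphenyl in place of ethynyl at that same place. Compound 3 gives up the 4-methoxyphenyl again, so a move in the opposite direction, toward a higher number, is expected. Within the data shown here, its size should be similar or somewhat smaller, since cyclopropyl is not ethynyl and no measured compound carries it. One step is thin evidence, so the range stays wide.

a 2.8-fold higher number from compound 2 to compound 3 (0.45 log units; beyond the scatter) is the estimated step. Compound 3 is estimated at 9000 nM in this assay with 3500 nM to 22000 nM as the expected range.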

Compound 3, half-maximal inhibitory concentration: 16100 nM
Estimate against measurement, compound 3: 1.8-fold (0.25 log units) below; the measured number falls inside the stated range.
By their numbers in this assay, from the lowest: compound 2; then compounds 1 and 3 (each within the scatter of the next).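

In this assay, cyclopropyl in place of 4-methoxyphenyl on a saturated chain carbon bound to a sulfur gives a 5.1-fold higher number from compound 2 to compound 3 (0.71 log units; beyond the scatter), so the lower number of compound 2 does not survive this exchange. Cyclopropyl in place of ethynyl at the same place gives a 1.2-fold higher number from compound 1 to compound 3 (0.08 log units; within the scatter), which leaves these two groups indistinguishable in this read-out. The earlier pair set 4-methoxyphenyl against ethynyl alone; with a second partner, the lower number now goes with 4-methoxyphenyl against both other groups, and ethynyl no longer stands as a single comparison point.

The compounds shown leave open whether the lower number depends on the aromatic ring itself or on its methoxy group, a question that a plain benzyl or a 4-hydroxybenzyl at this place would address. They also leave open whether a longer saturated chain, or a chain ending in an amine or a carboxylic acid, would follow compound 2 or stay with the other two. Nothing measured on these compounds accounts for the steps seen at this position.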